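Removing the chloro group from compound 2

This account rests on a few compounds, and the source may have more. Where it says the series, first, only, none or still open, it means among the compounds named here.

Values in a functional assay on HCT-116 cells (Homo sapiens) for antiproliferative activity, read by MTT assay, with a stated time of 72 h (a lower number here means a stronger inhibitor, a higher number a weaker inhibitor), so far:
Compound 1 `Cc1ccc(N2C(=O)COc3ccc(-c4cnc(Cl)c(NS(=O)(=O)c5ccc(F)cc5)c4)cc32)cc1` gives 34300 nM
Compound 2 `O=C1COc2ccc(-c3cnc(Cl)c(NS(=O)(=O)c4ccc(F)cc4)c3)cc2N1c1ccc(Cl)cc1` gives 27900 nM
Compound 3 `O=C1COc2ccc(-c3cnc(Cl)c(NS(=O)(=O)c4ccc(F)cc4)c3)cc2N1c1ccccc1` has not yet been measured

Compound 2 at 27900 nM lies within the scatter of compound 1, so the two values cannot be told apart. The next step leads to compound 3 and reads hydrogen in place of chloro on an aromatic carbon as the full difference. In words, this is hydrogen in place of chloro on an aromatic carbon, or 4-chlorophenyl to phenyl.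

For the measured compounds named here, one measured step bears on this change. Chloro in place of methyl at that same place gave a 1.2-fold lower number from compound 1 to compound 2 (0.09 log units; within the scatter) and so stayed within the scatter. Going by the values given here, no measured compound yet carries hydrogen there, which makes any reading for compound 3 an extrapolation from this single step. On that basis, no step beyond the scatter is expected in this assay in either direction. The expected change is a 1.1-fold higher number from compound 2 to compound 3 (0.03 log units; within the scatter) and no more. Compound 3 is estimated at 30000 nM with an expected range from 15000 nM to 60000 nM as the working window.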

Compound 3, half-maximal inhibitory concentration: 39800 nM
Estimate against measurement, compound 3: 1.3-fold (0.12 log units) below; low and high end bracket the measured number.
By their numbers in this assay, from the lowest: compounds 2, 1 and 3 (each within the scatter of the next).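

In this assay hydrogen in place of chloro on an aromatic carbon gives a 1.4-fold higher number from compound 2 to compound 3 (0.15 log units; within the scatter) and hydrogen in place of methyl at that same carbon gives a 1.2-fold higher number from compound 1 to compound 3 (0.06 log units; within the scatter) with both steps within the scatter. Until now this place had been read only as a swap between two substituents, whereas the unsubstituted phenyl now gives a third point, and hydrogen, methyl and chloro para to a large group cannot be told apart in this series, so none of the three changes here registers as a real step. The data offer no measured basis for explaining this lack of separation.

The compounds shown leave open whether an amine, a carboxylic acid or a longer alkyl chain on this same aromatic carbon would give a step beyond the scatter, as all three groups read so far are small and leave the numbers indistinguishable. They also leave open whether a change elsewhere on the shared core, with this ring held constant, would move the number further than any step seen here.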